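Acyl variation on the piperidine nitrogen: compound 2 to compound 3

A few compounds are considered here, and "the series" means these few. Any claim that something is new, unique, unknown or untested is made for them only; others in the source may bear on it.

Within the data shown here, compound 2 `Cc1nc(S(C)(=O)=O)ccc1Oc1ncnc(OC2CCN(C(=O)OC3(C(F)(F)F)CCC3)CC2)c1F` stands as the lowest of the two numbers so far in a functional assay on isolated protein for inhibition of Glucose-dependent insulinotropic receptor (Rattus norvegicus), read by HTRF and cAMP accumulation (on this read-out higher numbers stand for an effect only at larger amounts of compound and lower numbers for an effect already at smaller amounts), where compound 2 gives 63.3 nM; its nearest neighbour is compound 1 `Cc1nc(S(C)(=O)=O)ccc1Oc1ncnc(OC2CCN(C(=O)OC(C)(C)CF)CC2)c1F`, for which this assay gives 138 nM. Among the measured compounds shown here, the one measured step, a 2.2-fold lower number from compound 1 to compound 2 (0.34 log units; beyond the scatter), shows that a change of the group on the oxygen next to the carbonyl moved the number modestly but beyond the scatter.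

Compound 3 `CCC(F)(F)C(=O)N1CCC(Oc2ncnc(Oc3ccc(S(C)(=O)=O)nc3C)c2F)CC1` differs from compound 2 as follows: a group of 5 heavy atoms (3 carbon, 2 fluorine; no ring) in place of a group of 9 heavy atoms (5 carbon, 1 oxygen, 3 fluorine; one four-membered non-aromatic ring of carbon only), on a carbonyl carbon. For the measured compounds named here, no measured step covers a change of this kind, in which the oxygen and the ring both leave and a smaller open-chain group enters on the carbonyl carbon. Going by the values given here, the only guidance is that the larger fluorinated group gave the lower number. Compound 3 is therefore expected to give a somewhat higher number, a step of about a 2.4-fold higher number from compound 2 to compound 3 (0.37 log units; beyond the scatter), with wide uncertainty; the estimate for compound 3 is 150 nM, within 50 nM to 450 nM.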

Compound 3, half-maximal effective concentration: 69.2 nM
Compound 3: the middle estimate sits 2.2-fold (0.34 log units) above what was measured; the range from low to high includes it.
By their numbers in this assay, from the lowest: compounds 2, 3 and 1 (each within the scatter of the next, the first and the last beyond it).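

In this assay, the step of a 1.1-fold higher number from compound 2 to compound 3 (0.04 log units; within the scatter) shows that on this carbonyl carbon, 1,1-difluoropropyl, with no ring and no oxygen, gives a number that cannot be told apart from that of the larger group, while the step of a 2.0-fold lower number from compound 1 to compound 3 (0.30 log units; within the scatter) also stays inside the scatter. At this position, then, neither the oxygen on the carbonyl carbon nor the four-membered ring is needed for a number at this level among the three compounds. The data offer no explanation for how these groups come to read alike.

Going by these compounds, the oxygen and the ring leave together in the change to compound 3, so their separate contributions remain open. Also open, on these data alone, is whether plain propyl, a longer fluorinated chain or an amine on this carbonyl carbon would keep the number at this level.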